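The compounds below may be only part of what the source reports. "The series", "measured", "known", "first", "only" and "open" are said of these compounds alone.

Measured compounds:
compound 1 `Nc1sc(-c2ccc(Cl)cc2)c(-c2ccc(Cl)cc2)c1C(=O)N1CCCC1`: 6220 nM
compound 2 `Nc1sc(-c2ccc(Cl)cc2)c(-c2ccc(Cl)cc2)c1C(=O)N1CCCCC1=O`: 4940 nM

In a functional assay on PC-3 cells (Homo sapiens) for inhibition, read by sulforhodamine B assay, with a stated time of 72 h (a higher number here means a weaker inhibitor, a lower number a stronger inhibitor), compound 1 gives the highest of the two numbers shown, but the only measured step, a 1.3-fold lower number from compound 1 to compound 2 (0.10 log units; within the scatter), lies within the scatter, so the two compounds cannot be ordered. Compound 3 `COC(=O)c1c(N)sc(-c2ccc(Cl)cc2)c1-c1ccc(Cl)cc1` differs from compound 1 by methoxy in place of pyrrolidin-1-yl on a carbonyl carbon. For the measured compounds named here, no measured step exchanges the amide portion for an ester; the one step known swaps one ring amide for another and is within the scatter. On this basis compound 3 is expected to give 6500 nM, in the range 2200 nM to 20000 nM, with the estimated step of a 1.0-fold higher number from compound 1 to compound 3 (0.02 log units; within the scatter) not expected to exceed the scatter.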

Compound 3, half-maximal inhibitory concentration: 2780 nM
Compound 3: middle estimate off by 2.3-fold (0.37 log units), on the high side; the range from low to high includes it.
By their numbers in this assay, from the lowest: compounds 3, 2 and 1 (each within the scatter of the next, the first and the last beyond it).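

For the compounds shown here, on this carbonyl carbon, exchanging the ring amide pyrrolidin-1-yl for methoxy gives the first step beyond the scatter in this assay (a 2.2-fold lower number from compound 1 to compound 3 (0.35 log units; beyond the scatter)), though a modest one. The same exchange starting from 2-oxopiperidin-1-yl stays within the scatter (a 1.8-fold lower number from compound 2 to compound 3 (0.25 log units; within the scatter)), so compound 3 separates from compound 1 only, and a ring on this carbonyl is not needed to keep this level of activity. Nothing measured here explains the difference. Still open, as far as these compounds go, is how a carboxylic acid, an ethoxy group or a simple open-chain amine at this place would read.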